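Compound 1 to compound 3: a 4-methoxyphenyl step

The source may report more compounds than this note shows. Statements on the series, on what has been measured and on what is new or still open speak of the compounds shown alone.

In a physicochemical assay for solubility, read by HPLC, in phosphate buffer, measured as kinetic solubility, at pH 7.4 (on this read-out lower numbers stand for lower solubility and higher numbers for higher solubility), compound 1 (`CCC(=O)c1ccn(-c2ccc(S(N)(=O)=O)cc2)c1C`) gives 100000 nM and stands highest of the two numbers in hand. Compound 2 (`CCC(=O)c1cc(-c2ccc(Cl)cc2)n(C2CCN(S(N)(=O)=O)CC2)c1C`) gives 27800 nM and is the nearest, lower by more than the scatter. Compound 3 (`CCC(=O)c1cc(-c2ccc(OC)cc2)n(-c2ccc(S(N)(=O)=O)cc2)c1C`) is still unmeasured. It departs from compound 1 by one change (4-methoxyphenyl in place of hydrogen on an aromatic carbon): 4-methoxyphenyl in place of hydrogen on an aromatic carbon, next to the ring nitrogen. Within the data shown here, no measured step isolates this change, so the expectation is loose. A clear step down in this assay beyond the scatter is expected, with compound 2 at 27800 nM as the only lower reference. The estimated size is an 8.3-fold lower number from compound 1 to compound 3 (0.92 log units; beyond the scatter) on this read-out. For compound 3 the estimated value is 12000 nM within an expected range of 3000 nM to 40000 nM for a single measurement.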

Compound 3, solubility: 12800 nM
Compound 3: the middle estimate sits 1.1-fold (0.03 log units) below what was measured; the measured number falls inside the stated range.
By their numbers in this assay, from the lowest: compound 3; then compound 2; then compound 1.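

In this assay, among these compounds, 4-methoxyphenyl in place of hydrogen on an aromatic carbon, next to the ring nitrogen, gives a 7.8-fold lower number from compound 1 to compound 3 (0.89 log units; beyond the scatter), the first step that isolates a single change. This position is therefore not silent on this read-out: the step lies beyond the scatter, yet compound 3 still gives a number and not a limit, 12800 nM. No supporting measurement bears on what lies behind this step.

The compounds shown leave open whether a plain phenyl would step the same way here, or a phenyl carrying an amine or a carboxylic acid in place of the methoxy group. They also leave open whether a methyl group on this carbon would give a step of similar size.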